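Stability notes on a carbamate side-chain series

A few compounds are considered here, and "the series" means these few. Any claim that something is new, unique, unknown or untested is made for them only; others in the source may bear on it.

Measured compounds:
Compound 1 `CC(C)COC(=O)N1CCN(C(=O)c2nc(Nc3cc(C4CC4)[nH]n3)c3cc(Cl)ccc3n2)C[C@H]1C` gives 99% in a physicochemical assay, read by HPLC, in phosphate buffer, with a stated time of 2 h, at pH 7.4; on this read-out lower numbers stand for a less stable compound and higher numbers for a more stable compound.
Compound 2 `CC(C)C(=O)OCOC(=O)N1CCN(C(=O)c2nc(Nc3cc(C4CC4)[nH]n3)c3cc(Cl)ccc3n2)C[C@H]1C` gives 93.5% in this assay.
Compound 3 `CC(OC(=O)N1CCN(C(=O)c2nc(Nc3cc(C4CC4)[nH]n3)c3cc(Cl)ccc3n2)C[C@H]1C)OC(=O)C(C)(C)C` gives 90.5% in this assay.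

Compound 3 holds the lowest of the three numbers, but its distances to the others are small: a number 3 percentage points lower from compound 2 to compound 3 (within the scatter) and a number 8.5 percentage points lower from compound 1 to compound 3 (within the scatter), both within the scatter. All three compounds share the same core and differ only in the group on the carbamate oxygen.

Compound 4 `CC(OC(=O)C(C)C)OC(=O)N1CCN(C(=O)c2nc(Nc3cc(C4CC4)[nH]n3)c3cc(Cl)ccc3n2)C[C@H]1C` is the next member. Relative to compound 3 the change is hydrogen in place of methyl on a saturated chain carbon bound to a carbonyl carbon and two saturated chain carbons. Going by the values given here, the steps that bear on it are the earlier changes at the same carbamate side chain: a number 5.5 percentage points lower from compound 1 to compound 2 (within the scatter), a number 8.5 percentage points lower from compound 1 to compound 3 (within the scatter) and a number 3 percentage points lower from compound 2 to compound 3 (within the scatter), none of them beyond the scatter. The change from compound 3 to compound 4 is smaller than any of those, so no step beyond the scatter is expected in this assay.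

Compound 4 is therefore estimated at 91%, with a range from 82% to 98%. The expected step is a number 0.5 percentage points higher from compound 3 to compound 4 (within the scatter), within the scatter.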

Compound 4, percent of the compound remaining: 96.6%
Estimate against measurement, compound 4: 5.6 percentage points below; low and high end bracket the measured number.
By their numbers in this assay, from the lowest: compounds 3, 2, 4 and 1 (each within the scatter of the next).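

The tert-butyl to isopropyl change, on a saturated chain carbon bound to a carbonyl carbon and two saturated chain carbons, gives a number 6.1 percentage points higher from compound 3 to compound 4 (within the scatter) in this assay and so adds this place to those without a step beyond the scatter. The methyl in place of hydrogen on a saturated chain carbon bound to two oxygens gives a number 3.1 percentage points higher from compound 2 to compound 4 (within the scatter) and the whole 1-((isopropylcarbonyl)oxy)ethyl group in place of isobutyl gives a number 2.4 percentage points lower from compound 1 to compound 4 (within the scatter), so the four side chains cannot be told apart in this read-out. Nothing available bears on why these numbers fall as they do.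

Open, as far as these compounds go, is whether an amine or a carboxylic acid on the ester part, or a longer chain in place of isopropyl, would give a step beyond the scatter.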